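Dropping the fluorosulfonyl group from the terminal aromatic ring

The compounds below may be only part of what the source reports. "The series", "measured", "known", "first", "only" and "open" are said of these compounds alone.

Compound 1 `CC1(C)N=C(N)N=C(N)N1c1ccc(CCCCc2ccccc2S(=O)(=O)F)c(Cl)c1` and compound 2 `CC1(C)N=C(N)N=C(N)N1c1cccc(CCCCc2cccc(S(=O)(=O)F)c2)c1` share one core and a chain leading to a second aromatic ring. In an assay on isolated protein for inhibition of Dihydrofolate reductase (Mus musculus) (on this read-out higher numbers stand for higher potency (the scale is a negative logarithm) and lower numbers for lower potency), compound 1 gives 7.77 while compound 2 gives 8.1 and so stands highest of the two, the gap to compound 1 lying beyond the scatter. Compound 3 `CC1(C)N=C(N)N=C(N)N1c1cccc(CCCCc2ccccc2)c1` awaits measurement. Its difference from compound 2 is hydrogen in place of fluorosulfonyl on an aromatic carbon on the ring where the chain ends. Among the compounds with values here, no measured pair shows this same step, so the direction rests on the change alone; a moderate loss is expected, namely a number 0.60 log units lower from compound 2 to compound 3 (beyond the scatter) in this assay. Compound 3 is therefore estimated at 7.5 with a range from 6.8 to 8.2 in this assay.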

Compound 3, logarithm of the reciprocal of the active concentration, log(1/C): 8.35
The estimate for compound 3 lay 0.85 log units below the measured number, outside the stated range (above it).
By their numbers in this assay, from the lowest: compound 1; then compounds 2 and 3 (each within the scatter of the next).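

In this assay hydrogen in place of fluorosulfonyl on this aromatic carbon gives a number 0.25 log units higher from compound 2 to compound 3 (within the scatter) and so leaves compound 2 and compound 3 indistinguishable on this read-out. High potency at this position therefore does not require the fluorosulfonyl group, at least with this chain and core. The data shown offer no measured explanation for this result.

Open, from the compounds shown here alone, is whether a different group on the same aromatic carbon, such as an amine or a carboxylic acid, would separate from the unsubstituted phenyl of compound 3. Going by these compounds, the effect of a longer chain on compound 3 also remains open.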